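The compounds below may be only part of what the source reports. "The series", "measured", "known", "first", "only" and "open" are said of these compounds alone.

Measured so far:
- compound 1 `CCN1CCN(Cc2ccc(NC(=O)c3ccc(C)c(C#Cc4ccc(C(=O)NC)nc4)c3)cc2C(F)(F)F)CC1`: 3980 nM
- compound 2 `CCN1CCN(Cc2ccc(NC(=O)c3ccc(C)c(C#Cc4cncnc4)c3)cc2C(F)(F)F)CC1`: 2190 nM

Not yet measured:
- compound 3 `CCN1CCN(Cc2ccc(NC(=O)c3ccc(C)c(C#Cc4cnc5nccnc5c4)c3)cc2C(F)(F)F)CC1`

Going by the values given here, in a functional assay on BaF3 cells (Mus musculus) for antiproliferative activity (on this read-out higher numbers stand for an effect only at larger amounts of compound and lower numbers for an effect already at smaller amounts), compound 1 gives 3980 nM, and compound 2, the only other measured compound, lies within the scatter of it. Compound 3 differs from compound 1 as follows: a group of 10 heavy atoms (7 carbon, 3 nitrogen; one six-membered aromatic ring with 1 hetero atom, one six-membered aromatic ring with 2 hetero atoms) in place of a group of 10 heavy atoms (7 carbon, 2 nitrogen, 1 oxygen; one six-membered aromatic ring with 1 hetero atom), on a triple-bonded carbon. Among the compounds with values here, one measured step bears on this, at the same triple-bonded carbon: a 1.8-fold lower number from compound 1 to compound 2 (0.26 log units; within the scatter). Within the data shown here, with only that step to go on, the expected change in this assay is none beyond the scatter, and the estimated step is a 1.6-fold lower number from compound 1 to compound 3 (0.20 log units; within the scatter). For compound 3 the expected value is 2500 nM, with an estimated range of 800 nM to 7000 nM.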

Compound 3, half-maximal effective concentration: 3320 nM
Beside the measured number, compound 3's estimate is 1.3-fold (0.12 log units) below it, and the stated range covers the measured number.
By their numbers in this assay, from the lowest: compounds 2, 3 and 1 (each within the scatter of the next).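

In this assay, replacing either single-ring group on the triple-bonded carbon with the group carrying two six-membered aromatic rings gives no readable change: a 1.2-fold lower number from compound 1 to compound 3 (0.08 log units; within the scatter) and a 1.5-fold higher number from compound 2 to compound 3 (0.18 log units; within the scatter) both lie within the scatter. Neither the loss of the hydrogen-bond donor of 6-(methylcarbamoyl)pyridin-3-yl nor the step from 6 to 10 heavy atoms shifts the read-out beyond the scatter. No measurement at hand offers an explanation for this.

From the compounds shown here alone, whether any group at this carbon can move the number beyond the scatter remains open. A plain phenyl or an aminopyridinyl group here would test this.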